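A Fluorophenyl in Place of a Methyl

The source may report more compounds than this note shows. Statements on the series, on what has been measured and on what is new or still open speak of the compounds shown alone.

In a physicochemical assay for solubility, in phosphate buffer, at pH 6.5 (a higher number here means a more soluble compound, a lower number a less soluble compound), compound 3 `CCOc1cc(CN2CCC(NC(=O)c3cncc(C)c3)CC2)ccc1C` gives > 433 ug/mL, which is a limit and not a number. Put another way, (the limit of > 433 ug/mL in this assay, at which 1 of the 3 values shown sits). Compound 1 `CCOc1cc(CN2CCC(NC(=O)c3ccc(NC)nc3)CC2)cc(OCC)c1F` gives a true number, 330 ug/mL.

Compound 4 `CCOc1cc(CN2CCC(NC(=O)c3cncc(C)c3)CC2)ccc1-c1ccc(F)cc1` has 4-fluorophenyl in place of methyl on an aromatic carbon. Among the measured compounds shown here, no measured pair of compounds shows this change alone, so the guide is indirect. A clear fall in this assay is expected, since compound 2 `CCOc1cc(CN2CCC(NC(=O)c3cncc(C)c3)CC2)cc(OCC)c1-c1ccc(F)cc1`, which also carries 4-fluorophenyl, gives 94 ug/mL. The expected change is an at least 3.6-fold lower number from compound 3 to compound 4 (0.55 log units; beyond the scatter), a downward step larger than the usual scatter. For compound 4 the estimate is 120 ug/mL, with an expected range of 40 ug/mL to 350 ug/mL.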

Compound 4, solubility: 101 ug/mL
The estimate for compound 4 lay 1.2-fold (0.07 log units) above the measured number, within the range that was stated.
By their numbers in this assay, from the lowest: compounds 2 and 4 (each within the scatter of the next); then compound 1. At a limit, above all of these: compound 3.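

In this assay, 4-fluorophenyl in place of methyl on this aromatic carbon now has a direct reading, an at least 4.2-fold lower number from compound 3 to compound 4 (0.63 log units; beyond the scatter), where earlier compounds gave only indirect guidance. On these data alone, its true size stays unknown because compound 3 stands at a limit: (the limit of > 433 ug/mL in this assay, at which 1 of the 4 values shown sits). With 4-fluorophenyl present, hydrogen in place of ethoxy gives a 1.1-fold higher number from compound 2 to compound 4 (0.03 log units; within the scatter), so these two compounds cannot be told apart. Still open, as far as these compounds go, is how a group such as an amine or a carboxylic acid on this carbon would read in this assay, and whether a smaller halogen alone would lower the number.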